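The compounds below may be only part of what the source reports. "The series", "measured", "known", "first", "only" and "open" are said of these compounds alone.

Measured in a functional assay for inhibition, with Homo sapiens as the target; a lower number here means that less compound is needed, a higher number that more compound is needed for the effect
compound 1 (`CC(=O)Nc1ccc(C2=NNC(=O)CC2)cc1`) gives 1 ug/mL
compound 2 (`CCC(=O)Nc1ccc(C2=NNC(=O)CC2)cc1`) gives 0.64 ug/mL
compound 3 (`CCC(C)NCC(=O)Nc1ccc(C2=NNC(=O)CC2)cc1`) gives about 21.5 ug/mL

Compound 3 has the highest of the three numbers. Compound 4 (`CCN(CC)CC(=O)Nc1ccc(C2=NNC(=O)CC2)cc1`) has diethylamino in place of (sec-butyl)amino on a saturated chain carbon bound to a carbonyl carbon. The bearing steps are the large ones that install (sec-butyl)amino (a 22-fold higher number from compound 1 to compound 3 (1.33 log units; beyond the scatter)) and (a 34-fold higher number from compound 2 to compound 3 (1.53 log units; beyond the scatter)). The step (a 1.6-fold lower number from compound 1 to compound 2 (0.19 log units; within the scatter)) lies within the scatter. No measured step exchanges one amino group for another, so the size here is not directly shown. Compound 4 keeps an amino group in that place, as does compound 3 (about 21.5 ug/mL). The expected step (a 1.1-fold lower number from compound 3 to compound 4 (0.03 log units; within the scatter)) stays within the scatter in this assay with no clear direction. For compound 4 the estimate is 20 ug/mL (expected range 6 ug/mL to 60 ug/mL).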

Compound 4, half-maximal effective concentration: about 10 ug/mL
Compound 4: the middle estimate sits 2.0-fold (0.30 log units) above what was measured, within the range that was stated.
By their numbers in this assay, from the lowest: compounds 2 and 1 (each within the scatter of the next); then compound 4; then compound 3.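

In this assay the exchange of one amino group for another at this place, on a saturated chain carbon bound to a carbonyl carbon, has a measurable but modest effect (a 2.2-fold lower number from compound 3 to compound 4 (0.33 log units; beyond the scatter)). Diethylamino, which carries no hydrogen-bond donor, still leaves the number well above those of the compounds without an amino group (a 10-fold higher number from compound 1 to compound 4 (1.00 log units; beyond the scatter); a 16-fold higher number from compound 2 to compound 4 (1.19 log units; beyond the scatter)). No supporting measurement accounts for the difference between the two amino groups.

From the compounds shown here alone, whether a cyclic amine such as piperidine or morpholine would behave like diethylamino remains open. So does the effect of a longer chain carrying diethylamino.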